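The compounds below may be only part of what the source reports. "The series", "measured", "known", "first", "only" and "open" are said of these compounds alone.

Compound 2 `CC1(C)[C@H]2CC[C@]1(C)N(Cc1cn(-c3cccc(Cl)c3)nn1)C(=O)C2` belongs to a set of three congeners that share one core and differ only in the group on an aromatic nitrogen. In a functional assay on PANC-1 cells (Homo sapiens) for inhibition, read by MTT assay, with a stated time of 24 h (a higher number here means a weaker inhibitor, a lower number a stronger inhibitor), compound 2 gives 260 nM. Compound 1 `CC1(C)[C@H]2CC[C@]1(C)N(Cc1cn(-c3ccc(F)cc3)nn1)C(=O)C2` gives 110 nM, and compound 3 `CC1(C)[C@H]2CC[C@]1(C)N(Cc1cn(-c3cccc(O)c3)nn1)C(=O)C2` gives 280 nM. On those numbers compound 2 stands second highest of the three; its nearest neighbour is compound 3, with the step of a 1.1-fold higher number from compound 2 to compound 3 (0.03 log units; within the scatter), and its furthest is compound 1, with the step of a 2.4-fold higher number from compound 1 to compound 2 (0.37 log units; beyond the scatter). Compound 4 `COc1cccc(-n2cc(CN3C(=O)C[C@@H]4CC[C@@]3(C)C4(C)C)nn2)c1` has not been measured; it differs from compound 2 by methoxy in place of chloro on an aromatic carbon. Among the compounds with values here, the single measured step at the same place, a 1.1-fold higher number from compound 2 to compound 3 (0.03 log units; within the scatter), did not move beyond the scatter, while the steps that exchanged the whole ring, a 2.4-fold higher number from compound 1 to compound 2 (0.37 log units; beyond the scatter) and a 2.5-fold higher number from compound 1 to compound 3 (0.41 log units; beyond the scatter), were modest. A step within the scatter is therefore expected in this assay, a 1.1-fold higher number from compound 2 to compound 4 (0.03 log units; within the scatter). Compound 4 is estimated at 280 nM, with a range from 130 nM to 600 nM.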

Compound 4, half-maximal inhibitory concentration: 860 nM
For compound 4 the middle estimate is 3.1-fold (0.49 log units) below the measured one, outside the stated range (above it).
By their numbers in this assay, from the lowest: compound 1; then compounds 2 and 3 (each within the scatter of the next); then compound 4.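

In this assay, chloro and hydroxy on this carbon did not separate, but methoxy does: the step is a 3.3-fold higher number from compound 2 to compound 4 (0.52 log units; beyond the scatter). Placing methyl on the oxygen of compound 3 also counts, as the step of a 3.1-fold higher number from compound 3 to compound 4 (0.49 log units; beyond the scatter) shows, so a free hydroxy and its methyl ether are not interchangeable at this position. The 3-methoxyphenyl group also lies well away from the 4-fluorophenyl group, with a 7.8-fold higher number from compound 1 to compound 4 (0.89 log units; beyond the scatter) as the widest step in the set, and nothing available bears on what lies behind these differences.

On these data alone, it remains open whether a longer chain on this oxygen, such as ethoxy, would continue the trend, or whether an amine on this carbon would behave like chloro and hydroxy. As far as these compounds go, it is also open whether a 4-methoxyphenyl group would give a number close to that of compound 1 or that of compound 4.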